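Ethoxy for methoxy on the aryl ring of compound 3

The compounds below may be only part of what the source reports. "The series", "measured", "known", "first", "only" and "open" are said of these compounds alone.

Compound 3 `COc1cccc(-c2ccc(C(=O)N(Cc3cccc(OCCCCCC(=O)O)c3)C(C)C)cc2)c1` reaches only a limit in an ADME assay on BJ cells (Homo sapiens) for cytotoxicity, read by CellTiter-Glo and resazurin assay, with a stated time of 72 h; a higher number here means that more compound is needed for the effect, a lower number that less compound is needed: its value of > 20900 nM is a limit, not a number (the limit of > 20900 nM in this assay, at which 1 of the 3 values shown sits). Compound 1 `CC(C)N(Cc1cccc(OCCCCCC(=O)O)c1)C(=O)c1ccc(-c2cccc3ccccc23)cc1` gives < 1.3 nM in this assay, also a limit (the limit of < 1.3 nM in this assay, at which 1 of the 3 values shown sits). Compound 2 `CC(C)N(Cc1cccc(OCCCCCC(=O)O)c1)C(=O)c1ccc(-c2ccoc2)cc1` likewise sits at a limit with > 26000 nM (the limit of > 26000 nM in this assay, at which 1 of the 3 values shown sits). The step of an at least 20000-fold higher number from compound 1 to compound 2 (4.30 log units; beyond the scatter) and the step of an at least 16000-fold higher number from compound 1 to compound 3 (4.20 log units; beyond the scatter) are both large; the step that the two limits leave unreadable from compound 2 to compound 3 cannot be read. Compound 4 `CCOc1cccc(-c2ccc(C(=O)N(Cc3cccc(OCCCCCC(=O)O)c3)C(C)C)cc2)c1` differs from compound 3 by methyl in place of hydrogen on a saturated chain carbon bound to an oxygen on an aromatic ring. Within the data shown here, no measured step touches this position; the measured steps exchange the whole aromatic substituent. A step that the limit leaves unreadable from compound 3 to compound 4 is expected, that is none beyond the scatter. Compound 4 is therefore expected near 25000 nM, within 5000 nM to 100000 nM, most likely reported again as a limit.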

Compound 4, half-maximal effective concentration: > 20800 nM
Compound 4: no number, only a limit; the forecaster's own chance of this, stated with the estimate: 85%; the middle value is on the limit's open side.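

In this assay, methoxy to ethoxy is the first change shown at this position, and compound 4 again gives only a limit, > 20800 nM. The steps to compound 4 from compound 2 and compound 3 cannot be read: both ends of each are limits. The 3-ethoxyphenyl group stays on the same open side as furan-3-yl and 3-methoxyphenyl, with an at least 16000-fold higher number from compound 1 to compound 4 (4.20 log units; beyond the scatter).

From the compounds shown here alone, whether a longer chain or an amine on this oxygen would bring a readable number remains open. So does which part of naphthalen-1-yl goes with the low limit of compound 1.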